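Benzyl halogen swaps in the imide series: solubility notes

The source may hold more compounds than are shown below. What is called first, only, known or untested is meant among the compounds shown, and "the series" means these compounds.

Compound 1 `Cc1noc(-c2nc(C)c3c(c2N)C(=O)N(Cc2ccc(F)cc2)C3=O)n1`, compound 2 `Cc1noc(-c2nc(C)c3c(c2N)C(=O)N(Cc2ccc(Cl)cc2)C3=O)n1` and compound 3 `Cc1noc(-c2nc(C)c3c(c2N)C(=O)N(Cc2ccccc2F)C3=O)n1` share one core and differ only in the benzyl group on the ring amide-type nitrogen. In a physicochemical assay for solubility, using the shake flask method, in simulated intestinal fluid, measured as kinetic solubility, with a stated time of 2 h, at 25 degrees C, at pH 6.5 (on this read-out lower numbers stand for lower solubility and higher numbers for higher solubility), compound 1 gives < 5000 nM, which is a limit of the assay and not a number. Compound 2 likewise gives < 5000 nM, a limit. Compound 3 gives < 5000 nM, again a limit. Accordingly a step that the two limits leave unreadable from compound 1 to compound 2, a step that the two limits leave unreadable from compound 1 to compound 3 and a step that the two limits leave unreadable from compound 2 to compound 3; every value shown sits at the limit of < 5000 nM in this assay, at which 3 of the 3 values shown sit.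

Compound 4 `Cc1noc(-c2nc(C)c3c(c2N)C(=O)N(Cc2ccccc2Cl)C3=O)n1` remains to be measured. It differs from compound 3 by chloro in place of fluoro on an aromatic carbon. The same kind of change separates compound 1 from compound 2, (chloro in place of fluoro on an aromatic carbon), though there the group stands para to a large group rather than ortho to a large group. The cores of compound 1 and compound 3 differ by 2-fluorophenyl in place of 4-fluorophenyl on a saturated chain carbon bound to an amide-type nitrogen in a ring.

The step expected from this change is a step that the limit leaves unreadable from compound 3 to compound 4. That expectation rests on compound 3 sitting at the limit of < 5000 nM in this assay, at which 3 of the 3 values shown sit, and on a step that the two limits leave unreadable from compound 1 to compound 2 being unreadable. Compound 4 is therefore estimated at 2000 nM, most likely again returned only as a limit.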

Compound 4, solubility: < 5000 nM
Compound 4 gave a limit, no number; the forecaster's own chance of this, stated with the estimate: 85%; the middle value does not contradict the limit.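

In this assay compound 4 gives < 5000 nM, a limit of the assay and not a number. No step can be read between compound 4 and compound 1, compound 2 or compound 3, because all of the values are limits: the limit of < 5000 nM in this assay, at which 4 of the 4 values shown sit.

The compounds shown leave open where any of the four truly lies in this assay, and whether chloro in place of fluoro on an aromatic carbon changes the read-out at all.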